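The source may hold more compounds than are shown below. What is called first, only, known or untested is meant among the compounds shown, and "the series" means these compounds.

Compounds measured in a functional assay on CHO cells for agonist activity at adenosine receptor A1 (Homo sapiens), read by fluorescence and ERK phosphorylation, with stated times of 30 min and 1.5 h, tested at 10 uM; a higher number here means a stronger effect of the compound at the concentration tested, a lower number a weaker effect:
compound 1, `Nc1scc(-c2ccccc2)c1C(=O)c1ccccc1`, gives 48%;
compound 2, `Nc1scc(-c2ccc(Br)cc2)c1C(=O)c1ccccc1`, gives 49%;
compound 3, `Nc1scc(-c2ccc(I)cc2)c1C(=O)c1ccccc1`, gives 50%.

Compound 3 holds the highest of the three numbers, yet its steps to the others, a number 1 percentage points higher from compound 2 to compound 3 (within the scatter) and a number 2 percentage points higher from compound 1 to compound 3 (within the scatter), both lie within the scatter, so no order among the three can be claimed. Compound 4, `Nc1scc(-c2ccc([N+](=O)[O-])cc2)c1C(=O)c1ccccc1`, differs from compound 3 in one place: nitro in place of iodo on an aromatic carbon. For the measured compounds named here, the steps that bear on this position, a number 1 percentage points higher from compound 1 to compound 2 (within the scatter) and the two just named, were all within the scatter, and none involved a nitro group, so the expectation rests only on the small effect of changing this position so far. A step of a number 2 percentage points lower from compound 3 to compound 4 (within the scatter) is expected, none beyond the scatter. Compound 4 is therefore estimated at 48%, with a range from 30% to 62%.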

Compound 4, a percentage reported as activity, at one concentration (the size of the read-out at that concentration, not a potency): 47%
The estimate for compound 4 lay 1 percentage points above the measured number; measured number inside the range.
By their numbers in this assay, from the lowest: compounds 4, 1, 2 and 3 (each within the scatter of the next).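

Nitro, unlike iodo, carries hydrogen-bond acceptors and more heavy atoms, yet in this assay the steps are a number 3 percentage points lower from compound 3 to compound 4 (within the scatter) and a number 2 percentage points lower from compound 2 to compound 4 (within the scatter) and also a number 1 percentage points lower from compound 1 to compound 4 (within the scatter). Hydrogen, bromo, iodo and nitro at this position therefore cannot be told apart by this read-out. Nothing available accounts for this result.

On these data alone, whether an amine, a carboxylic acid or a longer chain at this position would give a step beyond the scatter stays open. Also open, as far as these compounds go, is whether these four compounds would separate at another concentration.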